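An amine swap on the shared core, from compound 1 to compound 4

A few compounds are considered here, and "the series" means these few. Any claim that something is new, unique, unknown or untested is made for them only; others in the source may bear on it.

Compound 1, `CCc1ccc(NC2=CC(=O)c3c(nc4n3[C@H]3OC[C@@H](O)[C@H]3OC4)C2=O)cc1`, was tested in a functional assay on ECa-109 cells for inhibition, with ECa-109 cell line (Homo sapiens) as the target, read by sulforhodamine B assay; a lower number here means a stronger inhibitor, a higher number a weaker inhibitor. In this assay compound 1 gives only a limit, > 4000 nM, and not a number. Compound 2, `COc1ccc(NC2=CC(=O)c3nc4n(c3C2=O)[C@H]2OC[C@@H](O)[C@H]2OC4)cc1`, likewise reaches only a limit in this assay, > 4000 nM. Compound 3, `O=C1C=C(N2CCCCC2)C(=O)c2c1nc1n2[C@H]2OC[C@@H](O)[C@H]2OC1`, also stops at a limit in this assay, > 8000 nM. For the measured compounds named here, the single measured step, a step that the two limits leave unreadable from compound 2 to compound 3, cannot be read because the limit of > 4000 nM in this assay, at which 2 of the 3 values shown sit, and the limit of > 8000 nM in this assay, at which 1 of the 3 values shown sits, form its two ends. Compound 1 therefore stands at a limit, as do the two other compounds shown, with no ranking among them.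

Compound 4, `CCCN(CCC)C1=CC(=O)c2c(nc3n2[C@H]2OC[C@@H](O)[C@H]2OC3)C1=O`, differs from compound 1 by dipropylamino in place of (4-ethylphenyl)amino on a double-bonded ring carbon. Compound 4 has not yet been measured in this assay. Going by the values given here, no readable measured step bears on this change, and every value so far is a limit, so no size or direction of step beyond the scatter can be predicted. The estimate for compound 4 in this assay is 8000 nM, expected to lie between 2000 nM and 40000 nM. The step this estimate implies is expected to be a step that the limit leaves unreadable from compound 1 to compound 4.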

Compound 4, half-maximal inhibitory concentration: > 16000 nM
Compound 4: a limit, no number; the forecaster's own chance of this, stated with the estimate: 80%; at least 2.0-fold (0.30 log units) between middle value and limit.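

Compound 4, like compound 1, ends at a limit in this assay, so no size or direction can be read for the change from compound 1 to compound 4. The compounds shown leave open whether changing the amine on the shared core alters inhibition at all.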